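Swapping 4-nitrophenyl for 2,5-difluorophenyl

The compounds below may be only part of what the source reports. "The series", "measured", "known", "first", "only" and "open" are said of these compounds alone.

Compounds measured in a functional assay on Jurkat cells (Homo sapiens); a lower number here means a stronger inhibitor, a higher number a weaker inhibitor:
- Compound 1 `CC(C)[C@H](NC(=O)COc1cccc2ccccc12)C(=O)N[C@@H](CC(=O)O)C(=O)COc1ccc(OC(F)(F)F)cc1`: 29100 nM
- Compound 2 `CC(=O)Nc1cccc(OCC(=O)[C@H](CC(=O)O)NC(=O)[C@@H](NC(=O)COc2cccc3ccccc23)C(C)C)c1`: > 100000 nM, a limit of the assay
- Compound 3 `CC(C)[C@H](NC(=O)COc1cccc2ccccc12)C(=O)N[C@@H](CC(=O)O)C(=O)COc1ccc([N+](=O)[O-])cc1`: > 100000 nM, a limit of the assay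

Compound 3 stands only at a limit, > 100000 nM, and has no number of its own. Compound 4 `CC(C)[C@H](NC(=O)COc1cccc2ccccc12)C(=O)N[C@@H](CC(=O)O)C(=O)COc1cc(F)ccc1F` carries 2,5-difluorophenyl in place of 4-nitrophenyl on an oxygen on a saturated carbon. Within the data shown here, two measured steps bear on this change: an at least 3.4-fold higher number from compound 1 to compound 3 (0.53 log units; beyond the scatter) and an at least 3.4-fold higher number from compound 1 to compound 2 (0.53 log units; beyond the scatter). Going by these compounds, both are beyond the scatter, and both end at a limit, so their full size is unknown. Only compound 1 gives a number, 29100 nM, and compound 4 is expected to fall near it. A lower number is therefore expected in this assay, an estimated at least 4.0-fold lower number from compound 3 to compound 4 (0.60 log units; beyond the scatter). For compound 4 the expected value is 25000 nM, with an estimated range of 5000 nM to 100000 nM.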

Compound 4, half-maximal inhibitory concentration: > 100000 nM
Compound 4 gave a limit, no number; the forecaster's own chance of this, stated with the estimate: 30%; middle value at least 4.0-fold (0.60 log units) from the limit.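

In this assay, 2,5-difluorophenyl in place of 4-(trifluoromethoxy)phenyl on this oxygen gives an at least 3.4-fold higher number from compound 1 to compound 4 (0.53 log units; beyond the scatter). Of the four groups now seen at this position, only 4-(trifluoromethoxy)phenyl gives a number, and the fluorines of 2,5-difluorophenyl do not bring one back. The steps among compound 2, compound 3 and compound 4 cannot be read, so these three cannot be ranked: the limit of > 100000 nM in this assay, at which 3 of the 4 values shown sit.

Going by these compounds, how far compound 2, compound 3 and compound 4 lie past that limit remains open. So does whether a plain phenyl or a naphthyl group on this oxygen would give a number.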